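The compounds below may be only part of what the source reports. "The series", "measured", "known", "first", "only" and "open" are said of these compounds alone.

Measured values in an ADME assay on TZM cells (Homo sapiens) for cytotoxicity, with a stated time of 1 days; a higher number here means that more compound is tolerated, a lower number that less compound is tolerated:

- Compound 1 `Cc1cc(C#N)cc(C)c1Oc1nc(Nc2ccc(C#N)cc2)ncc1/C=C/C(N)=O`: in this assay compound 1 gives only a limit, > 243 nM.
- Compound 2 `Cc1cc(C#N)cc(C)c1Oc1nc(Nc2ccc(C#N)cc2)ncc1/C=C/C(=O)NC1CC1`: in this assay compound 2 gives only a limit, > 221 nM.
- Compound 3 `Cc1cc(C#N)cc(C)c1Oc1nc(Nc2ccc(C#N)cc2)ncc1/C=C/C(=O)NC1CCN(S(C)(=O)=O)C1`: in this assay compound 3 gives only a limit, > 179 nM.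

Compound 3 therefore stands at a limit, as do the other two values shown; no number places it above or below compound 1 or compound 2 in this assay. The next compound in the series is compound 4 `Cc1cc(C#N)cc(C)c1Oc1nc(Nc2ccc(C#N)cc2)ncc1/C=C/C(=O)NCC1CCN(S(C)(=O)=O)C1`, reached by (1-(methylsulfonyl)pyrrolidin-3-yl)methyl in place of 1-(methylsulfonyl)pyrrolidin-3-yl on an amide-type nitrogen.

The steps already measured on the same amide-type nitrogen bear on this change: a step that the two limits leave unreadable from compound 1 to compound 2, a step that the two limits leave unreadable from compound 1 to compound 3 and a step that the two limits leave unreadable from compound 2 to compound 3. None of them has a readable size, because both ends of each sit at a limit: the limit of > 179 nM in this assay, at which 1 of the 3 values shown sits, the limit of > 221 nM in this assay, at which 1 of the 3 values shown sits, and (the limit of > 243 nM in this assay, at which 1 of the 3 values shown sits). For the measured compounds named here, the measured material thus shows only that varying the group on this nitrogen has so far left every compound at the limit of this assay.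

The expected step is a step that the limit leaves unreadable from compound 3 to compound 4, nothing beyond the scatter, and most likely another limit rather than a number. For compound 4 the estimate in this assay is 300 nM, with a range from 150 nM to 3000 nM.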

Compound 4, half-maximal cytotoxic concentration: > 175 nM
Compound 4 was reported as a limit (the forecaster's own chance of this, stated with the estimate: 85%); the middle value does not contradict the limit.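

In this assay compound 4 gives only a limit, > 175 nM. The steps linking compound 4 to compound 1, compound 2 and compound 3 therefore cannot be read. Still open, going by these compounds, is the half-maximal cytotoxic concentration of each of these four compounds, and whether the group on the amide-type nitrogen alters it at all.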